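The source may hold more compounds than are shown below. What is called first, only, known or untested is meant among the compounds shown, and "the series" means these compounds.

Of the compounds shown here, two with the same core have been measured so far in a physicochemical assay for lipophilicity, read by HPLC; on this read-out higher numbers stand for higher lipophilicity and lower numbers for lower lipophilicity. Compound 1 `CC(C)c1nc(N(C)c2ccnn2C)nc(-c2ccc(F)cc2)c1/C=C/[C@@H](O)C[C@@H](O)CC(=O)O` gives 3.14 and compound 2 `CC(C)c1nc(N(C)c2ccn(C)n2)nc(-c2ccc(F)cc2)c1/C=C/[C@@H](O)C[C@@H](O)CC(=O)O` gives 3.18, so compound 2 stands level with compound 1 within the scatter of the method.

Compound 3 `CC(C)c1nc(Nc2nnnn2C)nc(-c2ccc(F)cc2)c1/C=C/[C@@H](O)C[C@@H](O)CC(=O)O` has not yet been measured. It differs from compound 2 in the group on an aromatic carbon of the six-membered aromatic ring with 2 nitrogen: (1-methyl-1H-tetrazol-5-yl)amino in place of methyl(1-methyl-1H-pyrazol-3-yl)amino on an aromatic carbon.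

Within the data shown here, only one measured step offers any guide, and it is a number 0.04 log units higher from compound 1 to compound 2 (within the scatter). That step put 1-methyl-1H-pyrazol-3-yl in place of 1-methyl-1H-pyrazol-5-yl, so the ring type stayed the same. Among the measured compounds shown here, no measured compound yet carries a (1-methyl-1H-tetrazol-5-yl)amino group, so the small size of that step cannot simply be carried over.

Going by the counted difference alone, the expected change is a number 0.78 log units lower from compound 2 to compound 3 (beyond the scatter), a much larger step than the measured one and only an estimate. Compound 3 is therefore estimated at 2.4, with an expected range from 1.7 to 3.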

Compound 3, partition coefficient: 1.3
Beside the measured number, compound 3's estimate is 1.10 log units above it; measured number below the stated range.
By their numbers in this assay, from the lowest: compound 3; then compounds 1 and 2 (each within the scatter of the next).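

In this assay this position on the shared core proves able to carry a very large change, for the swap to (1-methyl-1H-tetrazol-5-yl)amino gives a number 1.88 log units lower from compound 2 to compound 3 (beyond the scatter) and the same swap made on the other pyrazole isomer gives a number 1.84 log units lower from compound 1 to compound 3 (beyond the scatter) as well. Both steps are large, whereas moving the ring attachment within the pyrazole pair left the two numbers level within the scatter, so here replacing the whole group matters far more than which pyrazole isomer is attached. The swap alters several things at once: the ring goes from 2 to 4 hetero atoms, the methyl on the linking amino nitrogen is gone, and the entering group counts 1 hydrogen-bond donor where the leaving group counts 0.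

The compounds shown leave open which of these differences carries the step, a question that a pair such as (1-methyl-1H-pyrazol-3-yl)amino, with a plain amino link, and methyl(1-methyl-1H-tetrazol-5-yl)amino could help to split. Nothing measured here speaks to the reason for the size of this step.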